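Fluorine Added to the Bromophenyl Group of Compound 3

The source may report more compounds than this note shows. Statements on the series, on what has been measured and on what is new or still open speak of the compounds shown alone.

Compound 1 `CCNC(=O)c1cc(Oc2ccc(NC(=O)c3cc4cccnc4n(-c4ccccc4F)c3=O)cc2)ccn1` gives 260 nM in a functional assay on HT-29 cells (Homo sapiens) for antiproliferative activity, read by MTT assay, with a stated time of 72 h; a higher number here means a weaker inhibitor, a lower number a stronger inhibitor; compound 2 `CCNC(=O)c1cc(Oc2ccc(NC(=O)c3cc4cccnc4n(-c4ccc(Cl)cc4)c3=O)cc2)ccn1` gives 330 nM; compound 3 `CCNC(=O)c1cc(Oc2ccc(NC(=O)c3cc4cccnc4n(-c4ccc(Br)cc4)c3=O)cc2)ccn1` gives 1160 nM.

Compound 3 stands highest of the three: the steps are a 4.5-fold higher number from compound 1 to compound 3 (0.65 log units; beyond the scatter) and a 3.5-fold higher number from compound 2 to compound 3 (0.55 log units; beyond the scatter), while the step of a 1.3-fold higher number from compound 1 to compound 2 (0.10 log units; within the scatter) is small. Compound 4 `CCNC(=O)c1cc(Oc2ccc(NC(=O)c3cc4cccnc4n(-c4ccc(Br)cc4F)c3=O)cc2)ccn1` keeps the shared core and differs from compound 3 by fluoro in place of hydrogen on an aromatic carbon. Within the data shown here, none of the measured steps adds a fluoro group to a ring that already carries bromo; the only fluorine seen is in compound 1, and the steps of a 1.3-fold higher number from compound 1 to compound 2 (0.10 log units; within the scatter) and a 4.5-fold higher number from compound 1 to compound 3 (0.65 log units; beyond the scatter) do not separate its effect from the change of halogen. With no direct guide, the expected step of a 1.2-fold lower number from compound 3 to compound 4 (0.06 log units; within the scatter) in this assay is none beyond the scatter. Compound 4 is therefore estimated at 1000 nM, within 400 nM to 2500 nM.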

Compound 4, half-maximal inhibitory concentration: 2070 nM
The estimate for compound 4 lay 2.1-fold (0.32 log units) below the measured number; low and high end bracket the measured number.
By their numbers in this assay, from the lowest: compounds 1 and 2 (each within the scatter of the next); then compounds 3 and 4 (each within the scatter of the next).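

In this assay, adding fluoro to the 4-bromophenyl ring gives a 1.8-fold higher number from compound 3 to compound 4 (0.25 log units; within the scatter), so this single atom, ortho to a large group, has no clear effect here. Bromo added to the ring already carrying fluoro gives an 8.0-fold higher number from compound 1 to compound 4 (0.90 log units; beyond the scatter), a step beyond the scatter, and replacing 4-chlorophenyl with 4-bromo-2-fluorophenyl gives a 6.3-fold higher number from compound 2 to compound 4 (0.80 log units; beyond the scatter), although that step changes the halogen and adds fluoro together. Nothing available explains these steps. Still open, from the compounds shown here alone, is how a 4-chloro-2-fluorophenyl group would read, and whether a methoxy group or an amine in the fluoro's place would stay within the scatter.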